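Solubility Outlook for a Configurational Isomer, Compound 3

The compounds below may be only part of what the source reports. "The series", "measured", "known", "first", "only" and "open" are said of these compounds alone.

Compound 2 `C[C@H]1[C@@H](N)CN1c1cc2c(cc1F)c(=O)c(C(=O)O)cn2C1CC1` stands at the lower end of the two solubility numbers at hand. In a physicochemical assay for solubility, at pH 7.4 (on this read-out higher numbers stand for higher solubility and lower numbers for lower solubility), compound 2 gives 6.1 ug/mL. Going by the values given here, its only neighbour is compound 1 `CN[C@H]1CN(c2cc3c(cc2F)c(=O)c(C(=O)O)cn3C2CC2)[C@@H]1C`, which in this assay gives 9.2 ug/mL. The step of a 1.5-fold lower number from compound 1 to compound 2 (0.18 log units; within the scatter) lies within the scatter, so the two compounds cannot be placed in order on this read-out.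

Compound 3 `C[C@H]1[C@H](N)CN1c1cc2c(cc1F)c(=O)c(C(=O)O)cn2C1CC1` has not yet been measured in this assay. Compared with compound 2 it shows the following difference: the two compounds have the same atoms and bonds and differ only in configuration as drawn: 1 of 2 stereo elements differ; a stereocentre at a saturated ring carbon is drawn S in compound 2 and R in compound 3. Among the compounds with values here, no measured step bears directly on such a change: the single step from compound 1 to compound 2 swaps one group for another on an aromatic carbon and stays within the scatter, whereas here the atoms and bonds are unchanged. With nothing in the data pointing either way, the step of a 1.1-fold higher number from compound 2 to compound 3 (0.06 log units; within the scatter) is expected to remain within the scatter. The estimate for compound 3 in this assay is therefore 7 ug/mL, with a range from 3 ug/mL to 16 ug/mL.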

Compound 3, solubility: 9.9 ug/mL
Compound 3: middle estimate off by 1.4-fold (0.15 log units), on the low side, and the stated range covers the measured number.
By their numbers in this assay, from the lowest: compounds 2, 1 and 3 (each within the scatter of the next).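

In this assay, going by these compounds alone, inverting one stereocentre at a saturated ring carbon gives a 1.6-fold higher number from compound 2 to compound 3 (0.21 log units; within the scatter) and is the first reading on configuration at this position, where the earlier compounds offered only a swap of groups. That reading does not separate the two drawn forms, so on this read-out no preference for either configuration can be stated from this pair. The swap of the group of 7 heavy atoms for the group of 6 heavy atoms on an aromatic carbon now has a second reading, a 1.1-fold higher number from compound 1 to compound 3 (0.03 log units; within the scatter), and this one also stays inside the scatter, which leaves compounds 1, 2 and 3 without a firm order; the one structural fact that bears on the new pair is this: the fact that compounds 2 and 3 differ only in the configuration as drawn.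

On these data alone, the second stereocentre is drawn alike in compound 2 and compound 3, so what inverting it would do in this assay remains open, as does whether the two stereocentres act independently of each other. As far as these compounds go, it is also open whether a larger change at this aromatic carbon, such as a piperazine in place of the four-membered ring, would move the solubility beyond the scatter.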